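The compounds below may be only part of what the source reports. "The series", "measured", "known", "first", "only" and "open" are said of these compounds alone.

Of the compounds shown here, two have so far been measured in a functional assay on A549 cells (Homo sapiens) for cytotoxicity, read by MTT assay, with a stated time of 72 h; on this read-out lower numbers stand for stronger inhibition and higher numbers for weaker inhibition. Compound 1 `COc1ccc(-c2cc(=O)c3c(O)cc(OCCCCN4CCN(C)CC4)c(OC)c3o2)cc1` gives 2320 nM in this assay. Compound 2 `CN(C)CCCOc1c(OCc2ccccc2)cc(O)c2c(=O)cc(-c3ccccc3)oc12` gives 2910 nM in this assay, the highest of the two numbers; its nearest neighbour is compound 1, and the gap between them lies within the usual scatter of repeated measurements, so the two cannot be ranked against each other. Compound 3 `CN1CCN(CCCOc2c(OCc3ccccc3)cc(O)c3c(=O)cc(-c4ccccc4)oc23)CC1` has not yet been measured in this assay. It differs from compound 2 in one place: 4-methylpiperazin-1-yl in place of dimethylamino on a saturated chain carbon, three bonds along the chain from an oxygen on an aromatic ring. Compound 1 also carries a 4-methylpiperazin-1-yl group, but compound 1 and compound 2 differ in more than one place, so their two values show only that they sit within the scatter of each other. Among the measured compounds shown here, no measured pair isolates this exact exchange. The step expected from compound 2 to compound 3 is a 1.2-fold lower number from compound 2 to compound 3 (0.07 log units; within the scatter), a change of no size beyond the scatter in either direction. Compound 3 is therefore estimated at 2500 nM in this assay, with a range from 1200 nM to 5200 nM.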

Compound 3, half-maximal inhibitory concentration: 3940 nM
Compound 3: middle estimate off by 1.6-fold (0.20 log units), on the low side, and the stated range covers the measured number.
By their numbers in this assay, from the lowest: compounds 1, 2 and 3 (each within the scatter of the next).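

In this assay, among the compounds shown here, the exchange of 3-(dimethylamino)propyl for 3-(4-methylpiperazin-1-yl)propyl gives a 1.4-fold higher number from compound 2 to compound 3 (0.13 log units; within the scatter) and is the first measured step that isolates this one change. On a saturated chain carbon, three bonds along the chain from an oxygen on an aromatic ring, the small open dimethylamino group can therefore give way to the larger six-membered ring of 4-methylpiperazin-1-yl with no shift that stands out from repeat-to-repeat variation, so compound 2 and compound 3 cannot be ranked against each other. Nothing measured here offers an explanation for this result.

The compounds shown leave open whether a different end group at this place, such as morpholine or a primary amine, or a shorter or longer chain carrying the same 4-methylpiperazin-1-yl group, would move the number beyond the scatter. On these data alone, this exchange is also seen only once, on a single background, so it remains unknown whether it would behave the same way if the benzyloxy group on the shared core were replaced by a free hydroxyl.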